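From 3,4-dimethylphenyl to 3-bromophenyl on the sulfonamide nitrogen

This account rests on a few compounds, and the source may have more. Where it says the series, first, only, none or still open, it means among the compounds named here.

Values measured in a functional assay on M21 cells (Homo sapiens) for antiproliferative activity, read by sulforhodamine B assay, with a stated time of 48 h; on this read-out higher numbers stand for weaker inhibition and lower numbers for stronger inhibition
compound 1 `CCc1ccccc1NS(=O)(=O)c1ccc(N2CCNC2=O)cc1` gives 180 nM
compound 2 `Cc1ccc(NS(=O)(=O)c2ccc(N3CCNC3=O)cc2)cc1` gives 260 nM
compound 3 `Cc1ccc(NS(=O)(=O)c2ccc(N3CCNC3=O)cc2)cc1C` gives 94 nM

Compound 3 sits together with compound 1 on these numbers. The two are separated by a 1.9-fold lower number from compound 1 to compound 3 (0.28 log units; within the scatter) and cannot be ranked. Among the compounds with values here, the third value gives a clearer picture, with a 2.8-fold lower number from compound 2 to compound 3 (0.44 log units; beyond the scatter) as the one step that exceeds the noise.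

Compound 4 `O=C1NCCN1c1ccc(S(=O)(=O)Nc2cccc(Br)c2)cc1` changes one place, with 3-bromophenyl in place of 3,4-dimethylphenyl on a sulfonamide nitrogen. Within the data shown here, no measured compound carries bromine, so no step speaks to it directly. Among the measured compounds shown here, the nearest guide is the methyl step just described, the only measured change of a single group on the ring, and it is modest. Exchanging one substituted phenyl for another has also moved the number little, as a 1.4-fold higher number from compound 1 to compound 2 (0.16 log units; within the scatter) shows. Compound 4 gives up both methyl groups, so a small move back towards a higher number, meaning weaker inhibition, is expected. The expected step in this assay is a 1.8-fold higher number from compound 3 to compound 4 (0.26 log units; within the scatter) and no larger than those already seen. Compound 4 is estimated at 170 nM (expected range 60 nM to 480 nM).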

Compound 4, half-maximal inhibitory concentration: 59 nM
Compound 4: middle estimate off by 2.9-fold (0.46 log units), on the high side, and the stated range ends above it.
By their numbers in this assay, from the lowest: compounds 4, 3, 1 and 2 (each within the scatter of the next, the first and the last beyond it).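

In this assay, replacing 3,4-dimethylphenyl with 3-bromophenyl on the sulfonamide nitrogen gives a 1.6-fold lower number from compound 3 to compound 4 (0.20 log units; within the scatter) and so does not separate the two compounds, which means that one bromine on the ring serves as well here as two methyl groups, and that a ring without any methyl group can still sit at the low end of this series. The new ring does stand apart from two of the earlier ones, with a 4.4-fold lower number from compound 2 to compound 4 (0.64 log units; beyond the scatter) and a 3.1-fold lower number from compound 1 to compound 4 (0.48 log units; beyond the scatter), so this position accepts an atom other than carbon on the phenyl ring, and the numbers here are not tied to alkyl groups such as methyl or ethyl. No further information on this result is available.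

The compounds shown leave open whether this result belongs to bromine itself or would also be seen with another atom or group on the phenyl ring, such as chlorine, a methoxy group or an amine. They also leave open whether the same steps would appear in cells other than those of this single assay.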